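The compounds below may be only part of what the source reports. "The series", "measured", "known", "first", "only" and "open" are said of these compounds alone.

Compound 2 `Nc1scc(CN2CCN(c3c(F)cccc3F)CC2)c1C(=O)c1ccc(Cl)cc1` carries a 2,6-difluorophenyl on an amine nitrogen in a ring; in an assay on CHO cells for displacement of a labelled ligand from adenosine receptor A3 (Homo sapiens), read by scintillation counting, with a stated time of 120 min, tested at 10 uM (a higher number here means more inhibition at the concentration tested (going by the name of the read-out), a lower number less inhibition), compound 2 gives 4%. Compound 1 `CC(C)N1CCN(Cc2csc(N)c2C(=O)c2ccc(Cl)cc2)CC1` bears an isopropyl at that position, and in this assay compound 1 gives 0%. Going by the values given here, the single measured step, a number 4 percentage points higher from compound 1 to compound 2 (within the scatter), is within the scatter, so the two numbers cannot be told apart and both sit near the bottom of the scale.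

Compound 3 `Nc1scc(CN2CCN(c3c(Cl)cccc3Cl)CC2)c1C(=O)c1ccc(Cl)cc1` differs from compound 2 in one place: 2,6-dichlorophenyl in place of 2,6-difluorophenyl on an amine nitrogen in a ring. Among the compounds with values here, no measured step swaps one halogen for another on this aryl group, so the only guide is that swapping the whole group in compound 1 for the aryl in compound 2 changed nothing beyond the scatter. The step of a number 1 percentage points higher from compound 2 to compound 3 (within the scatter) is therefore expected to stay within the scatter, in no clear direction. For compound 3 in this assay the estimate is 5%, with a range from -10% to 20%.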

Compound 3, a percentage reported as inhibition, at one concentration (the size of the read-out at that concentration, not a potency): 1%
The estimate for compound 3 lay 4 percentage points above the measured number, within the range that was stated.
By their numbers in this assay, from the lowest: compounds 1, 3 and 2 (each within the scatter of the next).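

Going by these compounds alone, with 2,6-dichlorophenyl in place of 2,6-difluorophenyl, this assay gives a number 3 percentage points lower from compound 2 to compound 3 (within the scatter), so the first comparison of two halogens on this aryl group shows no readable difference. With 2,6-dichlorophenyl in place of isopropyl, the result is a number 1 percentage points higher from compound 1 to compound 3 (within the scatter), so a second aryl group also cannot be told apart from isopropyl on this amine nitrogen, and all three compounds stay near the bottom of the scale. No measurement shown here offers an explanation for how close these numbers lie.

From the compounds shown here alone, it remains open whether a different kind of group at this position, such as a carboxylic acid or a longer chain, would lift the number clear of the scatter. Numbers this low also leave open whether the groups compared so far differ at all in this assay.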